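Shortening the Hydroxyalkyl Chain on the Triazole

The compounds below may be only part of what the source reports. "The series", "measured", "known", "first", "only" and "open" are said of these compounds alone.

Compound 1 `CCCCc1cn(C(c2ccccc2)c2cc3cc(Br)ccc3nc2OC)nn1` gives 11.1% in an ADME assay on SK-OV-3 cells (Homo sapiens) for cytotoxicity, read by sulforhodamine B assay, with a stated time of 48 h, tested at 10 uM (on this read-out higher numbers stand for more inhibition at the one concentration tested (going by the name of the read-out) and lower numbers for less inhibition), and compound 2 `COc1nc2ccc(Br)cc2cc1C(c1ccccc1)n1cc(CCCO)nn1` gives 13.8% in the same assay. Compound 2 stands highest of these two numbers, though the step of a number 2.7 percentage points higher from compound 1 to compound 2 (within the scatter) lies within the scatter. Compound 3 `COc1nc2ccc(Br)cc2cc1C(c1ccccc1)n1cc(CCO)nn1` differs from compound 2 by hydroxy in place of hydroxymethyl on a saturated chain carbon, two bonds along the chain from an aromatic carbon. Within the data shown here, the only measured step concerns a different change and was small, so no step beyond the scatter is expected here, with a number 1.8 percentage points lower from compound 2 to compound 3 (within the scatter) as the estimated change. Compound 3 is therefore expected to give about 12%, ranging from 3% to 24%.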

Compound 3, a percentage reported as inhibition, at one concentration (the size of the read-out at that concentration, not a potency): 8.46%
Estimate against measurement, compound 3: 3.5 percentage points above; the range from low to high includes it.
By their numbers in this assay, from the lowest: compounds 3, 1 and 2 (each within the scatter of the next).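

In this assay, going from 3-hydroxypropyl to 2-hydroxyethyl on the triazole gives a number 5.3 percentage points lower from compound 2 to compound 3 (within the scatter), so the shorter hydroxyalkyl chain cannot be told apart from the longer one. Hydroxy in place of ethyl at the same place on the chain gives a number 2.6 percentage points lower from compound 1 to compound 3 (within the scatter), so this short chain also cannot be told apart from the chain without hydroxy. No other evidence on hand bears on these numbers. The compounds shown leave open whether an amine or a carboxylic acid at the end of this chain, or a much longer chain, would give a step beyond the scatter.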